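Coumarin acetamides: homologation of the ring-bound acetamido group

The compounds below may be only part of what the source reports. "The series", "measured", "known", "first", "only" and "open" are said of these compounds alone.

Measured so far:
compound 1 `COc1ccc2c(CCCNC(C)=O)cc(=O)oc2c1` — 43%
compound 2 `COc1cccc2oc(=O)c(NC(C)=O)cc12` — 18.8%

Both compounds were tested in an assay on CHO cells for displacement of a labelled ligand from melatonin receptor type 1A (Homo sapiens), read by scintillation counting, with a stated time of 60 min, tested at 100 nM; a lower number here means less inhibition, a higher number more inhibition at the concentration tested (going by the name of the read-out). Compound 2 stands lowest of the two numbers; its nearest neighbour is compound 1, whose inhibition lies higher by a difference beyond the scatter.

Compound 3 `COc1cccc2oc(=O)c(CNC(C)=O)cc12` is the next compound in the series and is not yet measured. It differs from compound 2 by one change: acetamidomethyl in place of acetamido on an aromatic carbon.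

For the measured compounds named here, no step between two measured compounds is recorded for this change, so its size is unknown. A modest step upward is expected, because compound 1 gives 43% with the acetamide set further from the core. The expected step from compound 2 to compound 3 is a number 11.2 percentage points higher from compound 2 to compound 3 (beyond the scatter), at about the edge of the scatter. Compound 3 is estimated at 30%, with a range from 12% to 52%.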

Compound 3, a percentage reported as inhibition, at one concentration (the size of the read-out at that concentration, not a potency): 25.1%
For compound 3 the middle estimate is 4.9 percentage points above the measured one; measured number inside the range.
By their numbers in this assay, from the lowest: compounds 2 and 3 (each within the scatter of the next); then compound 1.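

In this assay, acetamidomethyl in place of acetamido on this aromatic carbon, two atoms from the ring oxygen, gives a number 6.3 percentage points higher from compound 2 to compound 3 (within the scatter). At the concentration tested, this read-out therefore does not separate the two side chains at this position, so this change gives no measurable gain or loss here. No accompanying measurement bears on this result.

Still open, going by these compounds, is whether a longer chain at this aromatic carbon, such as acetamidoethyl or acetamidopropyl, or a primary amine or carboxylic acid in place of the acetamide, would separate from compound 2 and compound 3. Compound 1 differs from both in more than one place, so steps to it cannot be read, and the role of the position of the side chain on the shared core remains unresolved.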